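The source may hold more compounds than are shown below. What is called first, only, known or untested is meant among the compounds shown, and "the series" means these compounds.

Measured in a functional assay on Bel-7402 cells (Homo sapiens) for cytotoxicity, read by MTT assay, with a stated time of 72 h; a lower number here means a stronger inhibitor, a higher number a weaker inhibitor:
- compound 1 `C=C1C(=O)[C@@]23C(=O)OC[C@]4(C(=O)CCC(C)(C)[C@H]4C=O)[C@@H]2CC[C@@H]1[C@H]3OC(=O)c1ccc(C)cc1`: 1540 nM
- compound 2 `C=C1C(=O)[C@@]23C(=O)OC[C@]4(C(=O)CCC(C)(C)[C@H]4C=O)[C@@H]2CC[C@@H]1[C@H]3OC(=O)c1ccc(C(F)(F)F)cc1`: 3990 nM

Among the measured compounds shown here, of the two numbers so far, compound 2 has the higher, which makes it the weaker inhibitor of the pair in this assay. Next is compound 3 `C=C1C(=O)[C@@]23C(=O)OC[C@]4(C(=O)CCC(C)(C)[C@H]4C=O)[C@@H]2CC[C@@H]1[C@H]3OC(=O)c1ccc(F)cc1`, which differs from compound 2 as follows: fluoro in place of trifluoromethyl on an aromatic carbon. This puts fluoro in place of trifluoromethyl on an aromatic carbon, para to a large group.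

For the measured compounds named here, only one measured step bears on this change: a 2.6-fold higher number from compound 1 to compound 2 (0.41 log units; beyond the scatter), a modest rise on trifluoromethyl replacing methyl. Going by the values given here, no fluoro compound has been measured, so methyl in compound 1 is the only guide to what losing trifluoromethyl might do. A small move back towards the value of compound 1 at 1540 nM is expected. The expected change is a 1.8-fold lower number from compound 2 to compound 3 (0.26 log units; within the scatter), which may not clear the scatter. For compound 3 the estimated value is 2200 nM, with an expected range of 1000 nM to 4800 nM.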

Compound 3, half-maximal inhibitory concentration: 3750 nM
Compound 3: the middle estimate sits 1.7-fold (0.23 log units) below what was measured; low and high end bracket the measured number.
By their numbers in this assay, from the lowest: compound 1; then compounds 3 and 2 (each within the scatter of the next).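

Fluoro in place of trifluoromethyl gives a 1.1-fold lower number from compound 2 to compound 3 (0.03 log units; within the scatter) and so does not separate these two groups at this position in this assay. Fluoro in place of methyl gives a 2.4-fold higher number from compound 1 to compound 3 (0.39 log units; beyond the scatter) and is close in size to a 2.6-fold higher number from compound 1 to compound 2 (0.41 log units; beyond the scatter) so compound 1 remains the strongest of the three and methyl is the one group here that stands apart from the other two. Nothing available accounts for methyl standing apart from the two fluorine-bearing groups.

Whether methyl is itself favourable at this aromatic carbon or the two fluorine-bearing groups are unfavourable stays open, since no unsubstituted phenyl ester is among the compounds shown. As far as these compounds go, how an amine, a methoxy group or a carboxylic acid would read at the same place is also open.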